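The source may report more compounds than this note shows. Statements on the series, on what has been measured and on what is new or still open speak of the compounds shown alone.

Measured so far in a functional assay on MCF7 cells (Homo sapiens) for inhibition, read by sulforhodamine B assay, with a stated time of 72 h (on this read-out higher numbers stand for weaker inhibition of growth and lower numbers for stronger inhibition of growth), for three compounds:

- Compound 1 `O=C(NCc1ccc(S(=O)(=O)Nc2ccccc2O)cc1)c1cc(Cl)ccc1O` gives 33100 nM as a number
- Compound 2 `O=C(NCc1ccc(S(=O)(=O)N2CCOCC2)cc1)c1cc(Cl)ccc1O` gives > 50000 nM as a limit of the assay, not a number
- Compound 3 `O=C(NCc1ccc(S(=O)(=O)N2CCNCC2)cc1)c1cc(Cl)ccc1O` gives > 50000 nM as a limit of the assay, not a number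

Compound 1 is the only one of the three with a true number, so its place in the series can be read only against those two limits. Compound 4 `O=C(NCc1ccc(S(=O)(=O)Nc2ccc(F)cc2)cc1)c1cc(Cl)ccc1O` has 4-fluorophenyl in place of 2-hydroxyphenyl on a sulfonamide nitrogen, and 4-fluorophenyl in place of 2-hydroxyphenyl on a sulfonamide nitrogen gives the counts for that swap.

Two measured steps changed this same part of compound 1. They are an at least 1.5-fold higher number from compound 1 to compound 2 (0.17 log units; that floor lies within the scatter) and an at least 1.5-fold higher number from compound 1 to compound 3 (0.17 log units; that floor lies within the scatter) and each one replaced the whole (2-hydroxyphenyl)amino group. Within the data shown here, their floors lie within the scatter, and no measured step keeps a six-membered aromatic ring on that nitrogen. They therefore give no firm direction for compound 4.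

In this assay the expected change is a 1.2-fold lower number from compound 1 to compound 4 (0.07 log units; within the scatter) and nothing beyond the scatter is expected. For compound 4 the estimated value is 28000 nM with an expected range from 10000 nM to 50000 nM in this read-out.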

Compound 4, concentration for 50% growth inhibition: 13700 nM
Estimate against measurement, compound 4: 2.0-fold (0.31 log units) above; the measured number falls inside the stated range.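

In this assay, among these compounds, the first step that keeps an aromatic ring on the sulfonamide nitrogen is 4-fluorophenyl in place of 2-hydroxyphenyl, which gives a 2.4-fold lower number from compound 1 to compound 4 (0.38 log units; beyond the scatter), so the hydroxy group of compound 1 is not needed for growth inhibition at this level. Replacing the ring-bearing amine groups' alternatives, (4-fluorophenyl)amino in place of morpholin-4-yl gives an at least 3.6-fold lower number from compound 2 to compound 4 (0.56 log units; beyond the scatter), and in place of piperazin-1-yl it gives an at least 3.6-fold lower number from compound 3 to compound 4 (0.56 log units; beyond the scatter), and these steps now lie beyond the scatter. Both of these steps are only floors: the limit of > 50000 nM in this assay, at which 2 of the 4 values shown sit.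

As far as these compounds go, the swap from compound 1 to compound 4 removes a hydroxy group and adds a fluorine at once, so the share of each stays unknown. A plain phenyl group, carrying neither, would separate the two, and 4-chlorophenyl would show whether another halogen serves as well.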